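The compounds below may be only part of what the source reports. "The series", "measured", "known", "first", "only" and "open" are said of these compounds alone.

Measured so far in a functional assay on B16-F0 cells (Mus musculus) for inhibition, read by CCK-8 assay, with a stated time of 48 h; on this read-out lower numbers stand for stronger inhibition and higher numbers for weaker inhibition:
- compound 1 `COc1cc(-c2ccnc3cc(-c4ccc(Cl)cc4)nn23)cc(OC)c1OC`: 4090 nM
- compound 2 `C=Cc1ccc(-c2cc3nccc(-c4cc(OC)c(OC)c(OC)c4)n3n2)cc1`: 788 nM

Of these two compounds, compound 2 has the lower number, at 788 nM, and so is the stronger inhibitor in this assay. The next compound, compound 3 `COc1cc(-c2ccnc3cc(-c4ccc(-c5cnn(C)c5)cc4)nn23)cc(OC)c1OC`, has not yet been measured. It keeps the shared core and differs from compound 2 in one place: 1-methyl-1H-pyrazol-4-yl in place of vinyl on an aromatic carbon. For the measured compounds named here, only one measured step bears on this place: a 5.2-fold lower number from compound 1 to compound 2 (0.72 log units; beyond the scatter). That step, with vinyl in place of chloro, was modest but beyond the scatter. Going by the values given here, no measured compound carries a 1-methyl-1H-pyrazol-4-yl group, however, so the data give no firm direction for this new change. A step of similar size is therefore expected to be possible either way, with no clear shift beyond the scatter as the central expectation. The expected step is a 1.1-fold lower number from compound 2 to compound 3 (0.05 log units; within the scatter). The estimated value for compound 3 is 700 nM, with an expected range from 160 nM to 3000 nM.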

Compound 3, half-maximal inhibitory concentration: 1240 nM
Compound 3: the middle estimate sits 1.8-fold (0.25 log units) below what was measured, and the stated range covers the measured number.
By their numbers in this assay, from the lowest: compounds 2 and 3 (each within the scatter of the next); then compound 1.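

In this assay, the position on the six-membered aromatic ring, para to a large group, accepts a far bigger group than vinyl without a clear change: 1-methyl-1H-pyrazol-4-yl brings a five-membered aromatic ring and 2 hydrogen-bond acceptors, yet the swap gives a 1.6-fold higher number from compound 2 to compound 3 (0.20 log units; within the scatter) and stays within the scatter. Replacing chloro with this same group gives a 3.3-fold lower number from compound 1 to compound 3 (0.52 log units; beyond the scatter) and lies beyond the scatter, so vinyl is no longer the only replacement that moves the number down from that of compound 1, and two quite different groups now land within the scatter of each other. Nothing available here explains why chloro differs from these two groups or why they read alike.

The compounds shown leave open how an amine or a carboxylic acid at this position would read, and whether a plain phenyl ring would fall with compound 2 and compound 3 or with compound 1. Three groups are also too few to tell whether the number follows any simple trend with group size at this position.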